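Leucine and isoleucine amides on a shared aryloxyquinoxaline core

The source may report more compounds than this note shows. Statements on the series, on what has been measured and on what is new or still open speak of the compounds shown alone.

Measured so far in a functional assay on K562 cells (Homo sapiens) for antiproliferative activity, read by MTT assay, with a stated time of 48 h; a lower number here means a stronger inhibitor, a higher number a weaker inhibitor:
- compound 1, `COC(=O)[C@H](CC(C)C)NC(=O)c1ccc(Oc2nc3ccccc3nc2C)cc1`, gives 22600 nM
- compound 2, `CC[C@@H](C)[C@H](NC(=O)c1ccc(Oc2nc3ccccc3nc2C)cc1)C(=O)OC`, gives 38300 nM
- compound 3, `Cc1nc2ccccc2nc1Oc1ccc(C(=O)N[C@@H](CC(C)C)C(=O)O)cc1`, gives 19500 nM

All three numbers sit within the scatter of one another. The step of a 1.7-fold higher number from compound 1 to compound 2 (0.23 log units; within the scatter) is the change (sec-butyl in place of isobutyl on a saturated chain carbon bound to an amide-type nitrogen and a carbonyl carbon); the step of a 1.2-fold lower number from compound 1 to compound 3 (0.06 log units; within the scatter) is the change (hydrogen in place of methyl on an oxygen next to a carbonyl group); the step of a 2.0-fold lower number from compound 2 to compound 3 (0.29 log units; within the scatter) combines both.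

Compound 4, `CC[C@@H](C)[C@H](NC(=O)c1ccc(Oc2nc3ccccc3nc2C)cc1)C(=O)O`, has not been measured. It differs from compound 3 by sec-butyl in place of isobutyl on a saturated chain carbon bound to an amide-type nitrogen and a carbonyl carbon. Among the compounds with values here, this is the same change as the one from compound 1 to compound 2, at a place described in the same words, and the cores of compound 3 and compound 1 differ by hydrogen in place of methyl on an oxygen next to a carbonyl group.

The expected step of a 1.7-fold higher number from compound 3 to compound 4 (0.23 log units; within the scatter) rests on the earlier 1.7-fold higher number from compound 1 to compound 2 (0.23 log units; within the scatter), made on the methoxycarbonyl pair, and on compound 3 giving 19500 nM as the starting point. Compound 4 is therefore estimated to give 33000 nM in this assay, with a plausible range from 15000 nM to 70000 nM.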

Compound 4, half-maximal inhibitory concentration: 30500 nM
The estimate for compound 4 lay 1.1-fold (0.03 log units) above the measured number, and the stated range covers the measured number.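

In this assay sec-butyl in place of isobutyl on the carboxylic acid pair gives a 1.6-fold higher number from compound 3 to compound 4 (0.19 log units; within the scatter) and agrees with the step on the methoxycarbonyl pair: the same change on two cores in this assay, a 1.7-fold higher number (0.23 log units; within the scatter) from compound 1 to compound 2 and a 1.6-fold higher number (0.19 log units; within the scatter) from compound 3 to compound 4, 1.1-fold (0.03 log units) apart, within the scatter of two such steps. Hydrogen in place of methyl on an oxygen next to a carbonyl group gives a 1.3-fold lower number from compound 2 to compound 4 (0.10 log units; within the scatter) and also carries from one core to the other: the same change on two cores in this assay, a 1.2-fold lower number (0.06 log units; within the scatter) from compound 1 to compound 3 and a 1.3-fold lower number (0.10 log units; within the scatter) from compound 2 to compound 4, 1.1-fold (0.03 log units) apart, within the scatter of two such steps. Within the data shown here, with both changes together the result is a 1.3-fold higher number from compound 1 to compound 4 (0.13 log units; within the scatter) and, as every step here lies within the scatter, the agreement shows only that neither change moved the number beyond the scatter on either core, not that a step of measurable size carries over, and it rests on just these four compounds in a single assay.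

As far as these compounds go, it remains open whether a benzyl group or a longer chain on the saturated chain carbon bound to an amide-type nitrogen and a carbonyl carbon would give a step beyond the scatter. The same question stands for a primary amide in place of the carboxylic acid.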